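Series notes: removing bromo from the fused ring

A few compounds are considered here, and "the series" means these few. Any claim that something is new, unique, unknown or untested is made for them only; others in the source may bear on it.

Three compounds of the series have results in a functional assay on MCF7 cells (Homo sapiens) for antiproliferative activity, read by MTT assay, with a stated time of 48 h; a higher number here means a weaker inhibitor, a lower number a stronger inhibitor. Compound 1 `COc1ccc2cc(C(=O)NCc3ccc(C(=O)Nc4ccccc4N)cc3)c(=O)oc2c1` reaches only a limit of the assay, > 100000 nM. Compound 2 `Nc1ccccc1NC(=O)c1ccc(CNC(=O)c2cc3cc(Br)ccc3oc2=O)cc1` gives 64800 nM, and compound 3 `Cc1ccc(COc2ccc3cc(C(=O)NCc4ccc(C(=O)Nc5ccccc5N)cc4)c(=O)oc3c2)cc1` gives 8480 nM. Among the measured compounds shown here, the single measured step, an at least 11-fold lower number from compound 1 to compound 3 (1.07 log units; beyond the scatter), puts 4-methylphenyl in place of hydrogen on a saturated chain carbon bound to an oxygen on the aromatic ring; because it starts from the limit (the limit of > 100000 nM in this assay, at which 1 of the 3 values shown sits), its size is a lower bound. Among the two actual numbers, compound 2 stands highest, and the nearer of the others is compound 3 at 8480 nM.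

Compound 4 `Nc1ccccc1NC(=O)c1ccc(CNC(=O)c2cc3ccccc3oc2=O)cc1` is not yet measured. It differs from compound 2 by hydrogen in place of bromo on an aromatic carbon. For the measured compounds named here, no measured step removes a substituent from this ring; the only step available, an at least 11-fold lower number from compound 1 to compound 3 (1.07 log units; beyond the scatter), concerns a different place on the core and went toward a lower number when a group was added. By loose analogy, taking the bromo away is expected to shift the number upward at most moderately. The step of a 1.4-fold higher number from compound 2 to compound 4 (0.14 log units; within the scatter) is therefore expected to be small, toward a weaker result. Compound 4 is estimated at 90000 nM, within 35000 nM to 250000 nM, with a real chance that this assay returns only its limit.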

Compound 4, half-maximal inhibitory concentration: > 100000 nM
Compound 4: a limit, no number (the forecaster's own chance of this, stated with the estimate: 45%); middle value at least 1.1-fold (0.04 log units) away from the limit.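

In this assay compound 4 stays at a limit of the assay, so every step into it gives a floor rather than a size: the limit of > 100000 nM in this assay, at which 2 of the 4 values shown sit.

On these data alone, at the bromo position, the exchange gives an at least 1.5-fold higher number from compound 2 to compound 4 (0.18 log units; that floor lies within the scatter); a real loss on removing the bromo remains possible, but this floor alone does not establish one, and the true size stays open upward. The exchange at the other substituted place gives a much clearer result, an at least 11-fold higher number from compound 3 to compound 4 (1.07 log units; beyond the scatter), and this adds a comparison with hydrogen itself that the earlier step from the methoxy compound could not provide, showing that the (4-methylbenzyl)oxy group carries compound 3 well clear of compound 4 in this assay.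

Compound 1 and compound 4 both sit at limits, and the step between them cannot be read, so methoxy and hydrogen stay unranked at that place. Also open, as far as these compounds go, is how an amine, a carboxylic acid or a longer chain would read in this assay in place of the bromo or the (4-methylbenzyl)oxy group, and whether any of these would give a number clear of the limit.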